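The source may report more compounds than this note shows. Statements on the series, on what has been measured and on what is new or still open speak of the compounds shown alone.

Measured so far in a functional assay on the whole organism for inhibition, with Rattus norvegicus as the target, read by cytopathic effect and paw edema, at a dose of 100 mg/kg by the oral route; a lower number here means less inhibition, a higher number more inhibition at the dose given (going by the name of the read-out):

compound 1 `CCOC(=O)c1c(O)c2cccnc2n(-c2ccccc2)c1=O` gives 15.5%
compound 2 `COc1ccccc1NC(=O)c1c(O)c2cccnc2n(-c2ccccc2)c1=O` gives -10.1%

Compound 2 stands lowest of these two numbers; its nearest neighbour is compound 1, and the step of a number 25.6 percentage points lower from compound 1 to compound 2 (beyond the scatter) lies beyond the scatter. Compound 3 `O=C(Nc1ccncc1)c1c(O)c2cccnc2n(-c2ccccc2)c1=O` differs from compound 2 by pyridin-4-yl in place of 2-methoxyphenyl on an amide-type nitrogen. Among the compounds with values here, the one measured step, a number 25.6 percentage points lower from compound 1 to compound 2 (beyond the scatter), replaced ethoxy on a carbonyl carbon by (2-methoxyphenyl)amino, so no measured step shows the effect of exchanging one aryl group for another on the amide-type nitrogen. The estimated step is therefore small, a number 13.1 percentage points higher from compound 2 to compound 3 (beyond the scatter), with no clear direction. Compound 3 is expected to give about 3%, within -20% to 28%.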

Compound 3, a percentage reported as inhibition, in the whole organism at one dose (the size of the read-out at that dose, not a potency): 24.3%
Beside the measured number, compound 3's estimate is 21.3 percentage points below it; the range from low to high includes it.
By their numbers in this assay, from the lowest: compound 2; then compounds 1 and 3 (each within the scatter of the next).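

In this assay, putting pyridin-4-yl in place of 2-methoxyphenyl on the amide-type nitrogen gives a number 34.4 percentage points higher from compound 2 to compound 3 (beyond the scatter), so the group at this place can move the read-out strongly. Replacing ethoxy on the carbonyl carbon with (pyridin-4-yl)amino gives a number 8.8 percentage points higher from compound 1 to compound 3 (within the scatter), so the lower number of compound 2 does not hold for both amides shown. Nothing available here explains either step.

Still open, as far as these compounds go, is whether plain phenyl, pyridin-3-yl or cyclohexyl on this nitrogen would read like compound 2 or like compound 3.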